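Chloro on the furan-2-yl group of compound 2

The source may report more compounds than this note shows. Statements on the series, on what has been measured and on what is new or still open speak of the compounds shown alone.

For the measured compounds named here, in a functional assay on HeLa cells (Homo sapiens) for cytotoxicity, read by ELISA, with a stated time of 4 days (a higher number here means a weaker inhibitor, a lower number a stronger inhibitor), three compounds have numbers so far. Compound 1 `Cc1ccsc1-c1cc(-c2ccco2)cc(-c2ccccc2Cl)n1` gives 24000 nM, compound 2 `Cc1ccsc1-c1cc(-c2ccco2)cc(-c2ccc(Cl)cc2)n1` gives 24500 nM and compound 3 `Clc1ccc(-c2cc(-c3ccco3)cc(-c3ccc(Cl)s3)n2)cc1` gives 17000 nM. Compound 2 stands level with both of the others, as each gap to it lies within the scatter.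

Compound 4 `Cc1ccsc1-c1cc(-c2ccc(Cl)o2)cc(-c2ccc(Cl)cc2)n1` differs from compound 2 in one place, with furan-2-yl becoming 5-chlorofuran-2-yl: chloro in place of hydrogen on an aromatic carbon. This is chloro in place of hydrogen on an aromatic carbon.

Going by the values given here, no measured step touches this group, so the evidence is indirect. Exchanging the chlorophenyl groups gave a 1.0-fold higher number from compound 1 to compound 2 (0.01 log units; within the scatter). Exchanging the thiophene groups, which also puts a chloro on a five-membered aromatic ring, gave a 1.4-fold lower number from compound 2 to compound 3 (0.16 log units; within the scatter). Both steps stay within the scatter, although neither says anything directly about a change on the furan.

No step beyond the scatter is therefore expected in this assay, with only a slight lean towards a lower number, taken from the step of a 1.4-fold lower number from compound 2 to compound 3 (0.16 log units; within the scatter). The expected step is a 1.3-fold lower number from compound 2 to compound 4 (0.11 log units; within the scatter). For compound 4 the estimated value is 19000 nM, with an expected range of 9000 nM to 36000 nM.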

Compound 4, half-maximal inhibitory concentration: 29300 nM
Estimate against measurement, compound 4: 1.5-fold (0.19 log units) below; the measured number falls inside the stated range.
By their numbers in this assay, from the lowest: compounds 3, 1, 2 and 4 (each within the scatter of the next).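

For the compounds shown here, compounds 2 and 4 give the first direct reading at this furan position: in this assay, chloro in place of hydrogen on the aromatic carbon next to the ring oxygen gives a 1.2-fold higher number from compound 2 to compound 4 (0.08 log units; within the scatter). The earlier steps shown here changed only the chlorophenyl and thiophene groups, whereas this one shows that furan-2-yl and 5-chlorofuran-2-yl stand level in this assay when the 3-methylthiophen-2-yl and 4-chlorophenyl groups are held constant. Nothing measured in the series explains this result.

On these data alone, with chloro as the only replacement for hydrogen at this position, it remains open whether an amine, a carboxylic acid or a longer chain on the same carbon would produce a step beyond the scatter. As far as these compounds go, it is also open whether the 5-chlorofuran-2-yl group would stay level with furan-2-yl alongside other groups on the shared core, such as the 5-chlorothiophen-2-yl group of compound 3.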